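Methoxycarbonyl to benzyloxycarbonyl in compound 3

The source may hold more compounds than are shown below. What is called first, only, known or untested is meant among the compounds shown, and "the series" means these compounds.

Of the compounds shown here, two have numbers so far. In a functional assay on A549 cells (Homo sapiens) for cytotoxicity, read by MTT assay (a lower number here means a stronger inhibitor, a higher number a weaker inhibitor), compound 2 (`C=C1C(=O)[C@]23C[C@@]1(I)CC[C@H]2[C@@]12C=CC(=O)[C@](C)(C(=O)O1)[C@H]2[C@@H]3C(=O)OC`) gives 53200 nM, within the scatter of compound 1 (`C=C1C(=O)[C@]23C[C@@]1(F)CC[C@H]2[C@@]12C=CC(=O)[C@](C)(C(=O)O1)[C@H]2[C@@H]3C(=O)OCc1ccccc1`) at 64400 nM. Compound 3 (`C=C1C(=O)[C@]23C[C@@]1(I)CC[C@H]2[C@@]12C=CC(=O)[C@](C)(C(=O)O1)[C@H]2[C@@H]3C(=O)OCc1ccccc1`) is still unmeasured and differs from compound 2 by phenyl in place of hydrogen on a saturated chain carbon bound to an oxygen next to a carbonyl group, which reads as methoxycarbonyl to benzyloxycarbonyl. Going by the values given here, no measured pair isolates this change. Compound 1 also carries benzyloxycarbonyl and gives 64400 nM, so no large shift is expected in this assay. The expected 1.0-fold higher number from compound 2 to compound 3 (0.01 log units; within the scatter) stays within the scatter. Compound 3 is estimated at 55000 nM, with an expected range of 22000 nM to 100000 nM.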

Compound 3, half-maximal inhibitory concentration: 46000 nM
Compound 3: the middle estimate sits 1.2-fold (0.08 log units) above what was measured; measured number inside the range.
By their numbers in this assay, from the lowest: compounds 3, 2 and 1 (each within the scatter of the next).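

Methoxycarbonyl to benzyloxycarbonyl gives a 1.2-fold lower number from compound 2 to compound 3 (0.06 log units; within the scatter) in this assay and is now isolated by a measured pair. Iodo in place of fluoro on a saturated ring carbon, with benzyloxycarbonyl held constant, gives a 1.4-fold lower number from compound 1 to compound 3 (0.15 log units; within the scatter) and is also isolated by a measured pair. Going by these compounds alone, no evidence accompanies either step.

As far as these compounds go, whether a carboxylic acid or an amide in place of benzyloxycarbonyl would move the number beyond the scatter remains open. Chloro or bromo on that saturated ring carbon also remains untested among the compounds shown.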